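A few compounds are considered here, and "the series" means these few. Any claim that something is new, unique, unknown or untested is made for them only; others in the source may bear on it.

Measured in a physicochemical assay for solubility, measured as kinetic solubility, at pH 7.4; a higher number here means a more soluble compound, a lower number a less soluble compound:
- compound 1 `COc1cc(N2CCNCC2)ccc1Nc1nc(NC2CCCCC2)c2nc[nH]c2n1`: 19000 nM
- compound 2 `COc1cc(N2CCN(Cc3ccccn3)CC2)ccc1Nc1nc(NC2CCCCC2)c2nc[nH]c2n1`: 38000 nM
- compound 3 `COc1cc(N2CCC(C(=O)N3CCC(N(C)C)C3)CC2)ccc1Nc1nc(NC2CCCCC2)c2nc[nH]c2n1`: 38000 nM

Compound 3 gives 38000 nM, the same reading as compound 2 at the digits shown, and its value also lies within the usual scatter of that of compound 1. The three measured compounds therefore cannot be separated in this assay.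

Compound 4 `COc1cc(N2CCC(C(=O)N3CCOCC3)CC2)ccc1Nc1nc(NC2CCCCC2)c2nc[nH]c2n1` has not yet been measured. It carries morpholin-4-yl in place of 3-(dimethylamino)pyrrolidin-1-yl on a carbonyl carbon.

Only one measured step links two of these compounds, a 2.0-fold higher number from compound 1 to compound 2 (0.30 log units; within the scatter). It lies within the scatter and concerns a different change, on an amine nitrogen in a ring. Among the measured compounds shown here, no measured pair shows this exchange on a carbonyl carbon, so the evidence is thin, and no change beyond the scatter is expected.

The expected step is a 1.5-fold lower number from compound 3 to compound 4 (0.18 log units; within the scatter).

For compound 4 the estimate is 25000 nM, with an expected range of 10000 nM to 45000 nM.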

Compound 4, solubility: 19000 nM
Beside the measured number, compound 4's estimate is 1.3-fold (0.12 log units) above it; the measured number falls inside the stated range.
By their numbers in this assay, from the lowest: compounds 1, 4, 2 and 3 (each within the scatter of the next).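

In this assay, among the compounds shown here, putting morpholin-4-yl in place of 3-(dimethylamino)pyrrolidin-1-yl on a carbonyl carbon gives a 2.0-fold lower number from compound 3 to compound 4 (0.30 log units; within the scatter), the first measured step at this position. The two groups differ in ring size and in their heavy atoms, one with a five-membered ring and the other with a six-membered ring, yet this assay does not separate them. No measurement of any other property is available that would explain this reading.

Still open, going by these compounds, is whether a carboxylic acid or an open-chain amine on the same carbonyl carbon would give a reading that stands clear of the scatter. Every step shown so far lies within that scatter, so it remains unknown what, if anything, moves this number at this position.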